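A Second Chloro on a Weak Growth Inhibitor

The compounds below may be only part of what the source reports. "The series", "measured", "known", "first", "only" and "open" are said of these compounds alone.

In a functional assay on NCI/ADR-RES cells (Homo sapiens) for inhibition (a higher number here means a weaker inhibitor of growth, a lower number a stronger inhibitor of growth), compound 2 `O=S(=O)(/C=C/c1ccc(Cl)cc1)Cc1ccc(Nc2ncnc3ccccc23)cc1` stands at > 100000 nM, which is a limit of the assay and not a number. Compound 1 `O=S(=O)(/C=C/c1ccc(Cl)c(Cl)c1)Cc1ccc(Nc2ncnc3ccccc23)cc1` gives 22000 nM. Among the measured compounds shown here, the single measured step bearing on what follows is an at least 4.5-fold higher number from compound 1 to compound 2 (0.65 log units; beyond the scatter), with hydrogen in place of chloro on an aromatic carbon. Compound 3 `O=S(=O)(/C=C/c1ccc(Cl)cc1Cl)Cc1ccc(Nc2ncnc3ccccc23)cc1` carries the change (chloro in place of hydrogen on an aromatic carbon), from 4-chlorophenyl to 2,4-dichlorophenyl, ortho to a large group. Compound 1 holds its second chloro at another place, so that step guides only loosely. The expected change, of similar size and toward stronger inhibition, is an at least 3.3-fold lower number from compound 2 to compound 3 (0.52 log units; beyond the scatter). Compound 3 is estimated at 30000 nM, with an expected range of 10000 nM to 100000 nM.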

Compound 3, concentration for 50% growth inhibition: 5000 nM
Estimate against measurement, compound 3: 6.0-fold (0.78 log units) above; the measured number lies below the stated range.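

Chloro in place of hydrogen at this carbon, ortho to a large group, gives an at least 20-fold lower number from compound 2 to compound 3 (1.30 log units; beyond the scatter). The place of the second chloro counts as well as its presence, since moving from 3,4-dichlorophenyl to 2,4-dichlorophenyl gives a 4.4-fold lower number from compound 1 to compound 3 (0.64 log units; beyond the scatter). The first step is only a bound, because compound 2 stands at a limit of the assay: the limit of > 100000 nM in this assay, at which 1 of the 3 values shown sits.

On these data alone, whether a fluoro, methyl or methoxy group at this carbon would do what chloro does remains open. So does whether the gain would survive without the chloro group meta to it.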